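A few compounds are considered here, and "the series" means these few. Any claim that something is new, unique, unknown or untested is made for them only; others in the source may bear on it.

Working notes on the series. Compound 1 `C=C1C[C@]23C[C@@]1(O)CC[C@H]2c1ccc(O)c(C)c1[C@@H]3Cn1cc(-c2ccccc2)nn1` and compound 2 `C=C1C[C@]23C[C@@]1(O)CC[C@@H]2c1cccc(C)c1[C@@H]3Cn1cc(-c2ccccc2)nn1` share a core; the difference between the two cores is not broken down here. Compound 3 `C=C1C[C@]23C[C@@]1(O)CC[C@H]2c1ccc(O)c(C)c1[C@@H]3Cn1cc(-c2ccc(F)cc2)nn1` carries the change fluoro in place of hydrogen on an aromatic carbon relative to compound 1, and compound 4 `C=C1C[C@]23C[C@@]1(O)CC[C@@H]2c1cccc(C)c1[C@@H]3Cn1cc(-c2ccc(F)cc2)nn1` carries the same change, (fluoro in place of hydrogen on an aromatic carbon), relative to compound 2. In a functional assay on A549 cells (Homo sapiens) for cytotoxicity, read by MTT assay, with a stated time of 4 days (on this read-out lower numbers stand for stronger inhibition and higher numbers for weaker inhibition), compound 1 reaches only the limit > 20000 nM. Compound 2 likewise reaches only the limit > 20000 nM in this assay. Compound 3 too gives only the limit > 20000 nM in this assay. Hence a step that the two limits leave unreadable from compound 1 to compound 3, as the limit of > 20000 nM in this assay, at which 3 of the 3 values shown sit, sets out. For compound 4 the step that the limit leaves unreadable from compound 2 to compound 4 is estimated to remain unreadable. This rests on compound 2 sitting at its limit > 20000 nM. It rests too on the same change having given a step that the two limits leave unreadable from compound 1 to compound 3. Compound 4 is thus expected at 40000 nM, most likely again only a limit.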

Compound 4, half-maximal inhibitory concentration: > 20000 nM
Compound 4: only a limit was reported (the forecaster's own chance of this, stated with the estimate: 90%); the middle value does not contradict the limit.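

No step can be read from compound 2 to compound 4, because both compounds give only a limit: the limit of > 20000 nM in this assay, at which 4 of the 4 values shown sit.

The compounds shown leave open whether phenyl to 4-fluorophenyl changes cytotoxicity at all on either core.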